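The source may report more compounds than this note shows. Statements on the series, on what has been measured and on what is new or still open speak of the compounds shown alone.

The measured compounds are three. Compound 1 `CC(C)CSc1nc(N)nc2c1ncn2/C=C1/CC1(CO)CO` in an ADME assay on BCBL1 cells (Homo sapiens) for cytotoxicity, with a stated time of 7 days (on this read-out lower numbers stand for higher toxicity in this test and higher numbers for lower toxicity in this test), gives > 20000 nM, a limit of the assay. Compound 2 `CC(C)CNc1nc(N)nc2c1ncn2/C=C1/CC1(CO)CO` gives > 20000 nM, likewise a limit. Compound 3 `CCCCCCCCSc1nc(N)nc2c1ncn2/C=C1/CC1(CO)CO` gives > 20000 nM, again only a limit.

For the measured compounds named here, compound 3 therefore stands at the limit of > 20000 nM in this assay, at which 3 of the 3 values shown sit, where every value so far sits. Compound 4 `Nc1nc(NC2CCCC2)c2ncn(/C=C3/CC3(CO)CO)c2n1` differs from it in one place: cyclopentylamino in place of octylsulfanyl on an aromatic carbon. The measured steps that touch compound 3 are a step that the two limits leave unreadable from compound 1 to compound 3 and a step that the two limits leave unreadable from compound 2 to compound 3, and the remaining one is a step that the two limits leave unreadable from compound 1 to compound 2; none of them yields a readable size, so no direction in this assay can be drawn from them. Compound 4 is accordingly expected to remain at the limit, with an estimate of 20000 nM spanning 10000 nM to 40000 nM, meaning an expected step of a number no higher from compound 3 to compound 4 (the limit leaves the size open).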

Compound 4, half-maximal cytotoxic concentration: 71700 nM
Compound 4: the middle estimate sits 3.6-fold (0.55 log units) below what was measured; the whole stated range lies below it.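

The steps from compound 1, compound 2 and compound 3 to compound 4 cannot be read, because those three compounds give only a limit: the limit of > 20000 nM in this assay, at which 3 of the 4 values shown sit.

The compounds shown leave open whether any of these changes on the aromatic carbon shifts cytotoxicity, and by how much.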